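This account rests on a few compounds, and the source may have more. Where it says the series, first, only, none or still open, it means among the compounds named here.

Working notes on the series. Compound 1 `CCOC(=O)c1c(-c2cccc(OCC)c2)[nH]c2cc(OC)ccc2c1=O` is the reference in an ADME assay on HepG2 cells (Homo sapiens) for cytotoxicity, read by luminescence, with a stated time of 72 h; on this read-out lower numbers stand for an effect already at smaller amounts and higher numbers for an effect only at larger amounts of compound. In this assay compound 1 gives > 21500 nM, which is a limit of the assay and not a number. Compound 2 `CCOC(=O)c1c(-c2cccc(C(F)(F)F)c2)[nH]c2cc(OC)ccc2c1=O` stands in this assay at > 21500 nM, likewise a limit. Compound 3 `CCOC(=O)c1c(-c2cccc(S(C)(=O)=O)c2)[nH]c2cc(OC)ccc2c1=O` stands in this assay at > 21500 nM, also a limit. The steps a step that the two limits leave unreadable from compound 1 to compound 2 and a step that the two limits leave unreadable from compound 1 to compound 3 cannot be read, and the same holds for a step that the two limits leave unreadable from compound 2 to compound 3, since all three values sit at the limit of > 21500 nM in this assay, at which 3 of the 3 values shown sit.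

Compound 4 `CCOC(=O)c1c(-c2cccc(O)c2)[nH]c2cc(OC)ccc2c1=O` differs from compound 1 in one place: hydrogen in place of ethyl on an oxygen on an aromatic ring. Within the data shown here, none of the measured steps touches this oxygen, so no step bears directly on the change; the series shows only that every variant tried at the 3-position of the phenyl ring stayed at the limit. Given that each value so far sits at the limit of > 21500 nM in this assay, at which 3 of the 3 values shown sit, compound 4 is expected to sit at the limit as well, the estimated step being a step that the limit leaves unreadable from compound 1 to compound 4. Compound 4 is estimated at 30000 nM, with a range of 15000 nM to 80000 nM.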

Compound 4, half-maximal effective concentration: > 21500 nM
Compound 4 ended at the assay's limit (the forecaster's own chance of this, stated with the estimate: 85%); the middle value is on the limit's open side.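

In this assay compound 4 also stays at a limit and not a number, so the steps to compound 4 from compound 1, compound 2 and compound 3 cannot be read: the limit of > 21500 nM in this assay, at which 4 of the 4 values shown sit.

The compounds shown leave open where the four true values lie beyond this limit.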